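Expected solubility after exchanging cyclohexyl for a benzyl group

The source may report more compounds than this note shows. Statements on the series, on what has been measured and on what is new or still open speak of the compounds shown alone.

Compound 1 `COc1ccc(F)cc1CNCCCNc1ccnc2cc(C3CCCCC3)ccc12` gives 4200 nM in a physicochemical assay for solubility, with a stated time of 18 h, at pH 7.4; on this read-out higher numbers stand for higher solubility and lower numbers for lower solubility. It stands level with compound 2 `c1coc(CNCCCNc2ccnc3cc(C4CCCCC4)ccc23)c1`, which gives 4200 nM, and with compound 3 `CCC(CC)c1ccc2c(NCCCNCc3ccco3)ccnc2c1`, which gives 4200 nM. The step of no change at the digits printed from compound 1 to compound 2 (within the scatter) and the step of no change at the digits printed from compound 2 to compound 3 (within the scatter) both left the read-out where it was. Compound 4 `COc1ccc(F)cc1CNCCCNc1ccnc2cc(Cc3cccc(C(F)(F)F)c3)ccc12` differs from compound 1 in one place: 3-(trifluoromethyl)benzyl in place of cyclohexyl on an aromatic carbon. Within the data shown here, only the step from compound 2 to compound 3 touched the same aromatic carbon, and it was flat, yet that swap exchanged one saturated group for another, whereas here an aromatic ring bearing trifluoromethyl enters; a modest fall, possibly no larger than the scatter, is expected, as a 1.4-fold lower number from compound 1 to compound 4 (0.15 log units; within the scatter). Compound 4 is therefore estimated at 3000 nM, within 1000 nM to 6500 nM.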

Compound 4, solubility: 4200 nM
Compound 4: middle estimate off by 1.4-fold (0.15 log units), on the low side; low and high end bracket the measured number.
By their numbers in this assay, from the lowest: compounds 1, 2, 3 and 4 (each within the scatter of the next).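

Exchanging cyclohexyl for 3-(trifluoromethyl)benzyl gave no change at the digits printed from compound 1 to compound 4 (within the scatter) in this assay. The flat result at this aromatic carbon therefore extends beyond one saturated group replacing another: it also holds for a group of 11 heavy atoms with an aromatic ring, against 6 in cyclohexyl. Nothing shown bears on why the read-out held.

The compounds shown leave open whether a group carrying an amine or a carboxylic acid at this carbon would move the read-out. They also leave open whether a longer chain between this carbon and the aromatic ring would do so.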